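A few compounds are considered here, and "the series" means these few. Any claim that something is new, unique, unknown or untested is made for them only; others in the source may bear on it.

Working notes on the series

Among the compounds with values here, compound 1 `O=C1N/C(=N/c2csc(-c3ccc(Cl)cc3)c2)S/C1=C\c1ccccc1` is the only member with a number in hand. In a functional assay on HCT-116 cells (Homo sapiens) for cytotoxicity, read by MTT assay, with a stated time of 72 h (a higher number here means a weaker inhibitor, a lower number a stronger inhibitor), compound 1 gives 11200 nM, so it stands alone as the sole reference point; compound 2 `CCCCCC/C=C1\S/C(=N\c2csc(-c3ccc(Cl)cc3)c2)NC1=O` belongs to the same set, but in this assay compound 2 gives "not determined" (no result reported), and nothing can be said of its potency. Within the data shown here, with one number and no second measured analogue, no step between measured compounds can be drawn, and the position of compound 1 is simply that of the single available value.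

Compound 3 `COc1ccc(/C=C2\S/C(=N\c3csc(-c4ccc(Cl)cc4)c3)NC2=O)cc1OC` keeps the shared core of compound 1 and differs in one place: 3,4-dimethoxyphenyl in place of phenyl on a double-bonded chain carbon bound to a double-bonded ring carbon. The change is confined to the group on the double-bonded chain carbon bound to the double-bonded ring carbon; everything else is unchanged.

Without a comparable step in this set, the size of the move is expected to be small, with a slight lean toward a lower number, estimated as a 1.4-fold lower number from compound 1 to compound 3 (0.15 log units; within the scatter) and not clearly beyond the scatter. In this assay compound 3 is expected to give 8000 nM, with a range of 3000 nM to 25000 nM.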

Compound 3, half-maximal inhibitory concentration: 1700 nM
Compound 3: the middle estimate sits 4.7-fold (0.67 log units) above what was measured; measured number outside the range, below it.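

In this assay, within the data shown here, the place on a double-bonded chain carbon bound to a double-bonded ring carbon responds to substitution on the aromatic ring: 3,4-dimethoxyphenyl in place of phenyl gives a 6.6-fold lower number from compound 1 to compound 3 (0.82 log units; beyond the scatter) and provides the first readable step. Both groups keep one six-membered aromatic ring of carbon only, so the step goes with the added substitution, which raises the count from 6 to 10 heavy atoms and from 0 to 2 hydrogen-bond acceptors, with no donors and no net charge on either side. No data at hand bear on the reason for this step.

Steps involving compound 2 cannot be read, so the effect of an open chain at this place relative to either aromatic group remains unknown. The compounds shown also leave open whether a single methoxy group would carry the step, and whether a hydroxyl group, an amine or a carboxylic acid on the same phenyl would give a similar result.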